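Chloro in Place of Fluoro: Expected Cytotoxicity of Compound 3

The source may hold more compounds than are shown below. What is called first, only, known or untested is meant among the compounds shown, and "the series" means these compounds.

Compound 1, `Oc1cc(C(F)(F)F)ccc1-c1nc(-c2ccccc2O)n(-c2ccccc2C(F)(F)F)n1`: 92.2%
Compound 2, `Oc1cc(C(F)(F)F)ccc1-c1nc(-c2ccccc2O)n(-c2cccc(F)c2)n1`: 98.3%

In a functional assay on PC-12 cells (Rattus norvegicus) for cytotoxicity, read by MTT assay, with stated times of 2 h and 24 h, tested at 10 uM (a lower number here means a weaker effect, a higher number a stronger effect of the compound at the concentration tested), compound 2 gives 98.3% and compound 1 gives 92.2%. Among the compounds with values here, only one step joins them: a number 6.1 percentage points higher from compound 1 to compound 2 (within the scatter), so the two compounds stand together, with compound 2 having the larger of two close numbers.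

Compound 3, `Oc1cc(C(F)(F)F)ccc1-c1nc(-c2ccccc2O)n(-c2cccc(Cl)c2)n1`, differs from compound 2 by chloro in place of fluoro on an aromatic carbon. Within the data shown here, no measured step changes this same position; the one step known, a number 6.1 percentage points higher from compound 1 to compound 2 (within the scatter), swapped the whole ring on the aromatic nitrogen and stayed within the scatter. A smaller change is therefore expected to move the number no further than the scatter: a number 2.3 percentage points lower from compound 2 to compound 3 (within the scatter). Compound 3 is estimated at 96%, in the range 86% to 100%.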

Compound 3, a percentage reported as activity, at one concentration (the size of the read-out at that concentration, not a potency): 100%
Beside the measured number, compound 3's estimate is 4 percentage points below it; the range from low to high includes it.
By their numbers in this assay, from the lowest: compounds 1, 2 and 3 (each within the scatter of the next).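

Chloro in place of fluoro is the first change shown at this position, and in this assay it leaves the number within the scatter (a number 1.7 percentage points higher from compound 2 to compound 3 (within the scatter)), so these two halogens cannot be told apart here. The larger change, 3-chlorophenyl in place of 2-(trifluoromethyl)phenyl on the aromatic nitrogen, also stays within the scatter (a number 7.8 percentage points higher from compound 1 to compound 3 (within the scatter)). No supporting data bear on why these numbers stay so close. From the compounds shown here alone, whether an amine or a carboxylic acid at this position would move the number beyond the scatter remains open. So does whether a lower concentration would separate these compounds.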